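The source may report more compounds than this note shows. Statements on the series, on what has been measured and on what is new or still open speak of the compounds shown alone.

Measured so far in a functional assay on cells (T-cell line, Homo sapiens) for inhibition; on this read-out lower numbers stand for stronger inhibition and higher numbers for weaker inhibition:
compound 1 `CCN1CCC(COC(c2ccccc2)c2ccccc2)CC1`: > 20000 nM
compound 2 `COc1ccc(CC2(CN3CCC(COC(c4ccccc4)c4ccccc4)CC3)CCCCC2)cc1`: 3400 nM

Compound 1 gives only > 20000 nM in this assay, which is a limit of the measurement and not a number. Where compound 1 stands is therefore known only as the limit of > 20000 nM in this assay, at which 1 of the 2 values shown sits, the weaker end of what the assay can report. Compound 2 gives 3400 nM in this assay, a value well inside the measurable range. Going by the values given here, no pair of measured compounds differs in a single place, so no measured step is available.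

Compound 3 `c1ccc(C(OCC2CCN(CC3CCc4ccccc4C3)CC2)c2ccccc2)cc1` has not yet been measured. Relative to compound 1 it differs in one place: 1,2,3,4-tetrahydronaphthalen-2-yl in place of methyl on a saturated chain carbon bound to an amine nitrogen in a ring. The expected step is an at least 6.6-fold lower number from compound 1 to compound 3 (0.82 log units; beyond the scatter), a move toward stronger inhibition and beyond the usual scatter, because compound 2 gives 3400 nM in this assay. Compound 3 is expected to give 3000 nM in this assay, with a range from 800 nM to 12000 nM.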

Compound 3, half-maximal inhibitory concentration: 5600 nM
The estimate for compound 3 lay 1.9-fold (0.27 log units) below the measured number, and the stated range covers the measured number.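

In this assay, going by these compounds alone, 1,2,3,4-tetrahydronaphthalen-2-yl in place of methyl on a saturated chain carbon bound to an amine nitrogen in a ring gives an at least 3.5-fold lower number from compound 1 to compound 3 (0.55 log units; beyond the scatter), the first step that can be read at this position and one that lies beyond the scatter. This single change is enough to bring the core of compound 1 inside the measurable range, with compound 3 at 5600 nM, a number rather than a limit. The step has a lower bound but no measured size, since compound 1 is known only as a limit of the assay: the limit of > 20000 nM in this assay, at which 1 of the 3 values shown sits.

The change brings in a non-aromatic ring and an aromatic ring together, so the step cannot tell whether one of them alone would suffice, and a single step cannot show how the number responds to other groups at this place. From the compounds shown here alone, whether a pyridine ring or a cyclohexyl group in the same place would give a similar number stays open, as does the effect of an amine or a carboxylic acid on the 1,2,3,4-tetrahydronaphthalen-2-yl group.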